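What compound 4 may show after one ring swap

The compounds below may be only part of what the source reports. "The series", "measured", "known", "first", "only" and "open" are said of these compounds alone.

Values so far in an ADME assay on MDCK-II cells (Canis lupus familiaris) for permeability (on this read-out lower numbers stand for lower permeability and higher numbers for higher permeability), are these
- compound 1 `Cc1ccc(NC(=O)c2cc(Oc3ccc(S(C)(=O)=O)cc3)cc(OC(C)C)c2)nc1` gives 4.4 10^-6 cm/s
- compound 2 `CC(C)Oc1cc(Oc2ccc(S(C)(=O)=O)cc2)cc(-c2ccnc(=O)[nH]2)c1` is "not determined" (no result reported)
- compound 3 `CC(C)Oc1cc(Oc2ccc(S(C)(=O)=O)cc2)cc(-c2cncc(=O)[nH]2)c1` gives 94 10^-6 cm/s

Compound 3 holds the highest of the two numbers available. For the measured compounds named here, the only measured step is a 21-fold higher number from compound 1 to compound 3 (1.33 log units; beyond the scatter) and it is large, beyond the scatter. In that step, a group of 7 heavy atoms (4 carbon, 2 nitrogen, 1 oxygen; one six-membered aromatic ring with 2 hetero atoms) took the place of a group of 10 heavy atoms (7 carbon, 2 nitrogen, 1 oxygen; one six-membered aromatic ring with 1 hetero atom). Compound 2 offers no number, so it cannot guide the estimate.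

Compound 4 `Cc1cnc(-c2cc(Oc3ccc(S(C)(=O)=O)cc3)cc(OC(C)C)c2)[nH]c1=O` has not been measured. Its change from compound 3 is a group of 8 heavy atoms (5 carbon, 2 nitrogen, 1 oxygen; one six-membered aromatic ring with 2 hetero atoms) in place of a group of 7 heavy atoms (4 carbon, 2 nitrogen, 1 oxygen; one six-membered aromatic ring with 2 hetero atoms), on an aromatic carbon on an aromatic carbon of a six-membered aromatic ring of carbon only. Both groups contain one six-membered aromatic ring with 2 hetero atoms, so this swap is smaller than the one behind a 21-fold higher number from compound 1 to compound 3 (1.33 log units; beyond the scatter) and a much smaller move is expected. In this assay the expected result is no step beyond the scatter, perhaps with a slight drop. The estimate is a 1.3-fold lower number from compound 3 to compound 4 (0.13 log units; within the scatter) and this is expected to stay within the scatter. The expected value for compound 4 is 70 10^-6 cm/s within an estimated range running from 25 10^-6 cm/s to 160 10^-6 cm/s in repeat measurements.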

Compound 4, apparent permeability: 17 10^-6 cm/s
Estimate against measurement, compound 4: 4.1-fold (0.61 log units) above; the measured number lies below the stated range.
By their numbers in this assay, from the lowest: compound 1; then compound 4; then compound 3.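

In this assay, the read-out proves sensitive to a very small edit at this position on the ring of carbon only: a group of 8 heavy atoms in place of a group of 7 gives a 5.5-fold lower number from compound 3 to compound 4 (0.74 log units; beyond the scatter) even though both groups hold one six-membered aromatic ring with 2 hetero atoms and the same counts of hydrogen-bond donors and acceptors. The earlier comparison, a 21-fold higher number from compound 1 to compound 3 (1.33 log units; beyond the scatter) for a far larger swap, could not show that a change this slight also moves the number beyond the scatter, so ring type alone does not set the value here. For the compounds shown here, compound 4 still keeps an advantage, with a 3.9-fold higher number from compound 1 to compound 4 (0.59 log units; beyond the scatter) in this assay, but that step is clearly smaller than the one reached with compound 3, and nothing available explains the difference between compound 3 and compound 4.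

With only one larger group shown at this place, it remains open whether the number depends on the size of the added carbon group or on where it sits on the ring. An ethyl group, a fluorine atom or an amine in that same spot could push the number lower still or return it toward that of compound 3, and the compounds shown cannot say which.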